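The compounds below may be only part of what the source reports. "The series", "measured", "known", "first", "only" and "open" are said of these compounds alone.

Compound 1 `c1c[nH]c(-c2ccccc2OCC2=NCCN2)c1`: 99%
Compound 2 `c1ccc(-c2cc[nH]n2)c(OCC2=NCCN2)c1`: 119%

In a functional assay with Alpha-1A adrenergic receptor (Homo sapiens) as the target, read by calcium flux (a lower number here means a smaller maximal response, a higher number a larger maximal response), compound 2 stands as the higher of the two numbers; the step of a number 20 percentage points higher from compound 1 to compound 2 (beyond the scatter) sets it apart from compound 1, beyond the scatter. Compound 3 `c1ccc(-c2ncc[nH]2)c(OCC2=NCCN2)c1` differs from compound 2 by 1H-imidazol-2-yl in place of 1H-pyrazol-3-yl on an aromatic carbon. Within the data shown here, only one measured step bears on this, and it swapped a different five-membered ring, with a modest rise. Among the measured compounds shown here, no step of the same kind exists, so a change of little size is expected in either direction. The step of a number 9 percentage points lower from compound 2 to compound 3 (within the scatter) is the estimated outcome. For compound 3 the expected value is 110%, within a range from 85% to 135%.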

Compound 3, largest response reached (reported as maximum), in percent of the reference or control that the assay uses: 122%
The estimate for compound 3 lay 12 percentage points below the measured number, and the stated range covers the measured number.
By their numbers in this assay, from the lowest: compound 1; then compounds 2 and 3 (each within the scatter of the next).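

In this assay the step of a number 3 percentage points higher from compound 2 to compound 3 (within the scatter) shows that 1H-imidazol-2-yl and 1H-pyrazol-3-yl, which hold the same atoms joined differently, cannot be told apart at this place on the aromatic carbon. The step of a number 23 percentage points higher from compound 1 to compound 3 (beyond the scatter) shows that the rise over 1H-pyrrol-2-yl is not limited to 1H-pyrazol-3-yl, as a second ring gives it too. Nothing available explains why these two rings match. Still open, on these data alone, is whether a six-membered pyridine ring, an amine or a carboxylic acid at this place would keep the response.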